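Urea and thiourea benzyloxybenzoyl series, halogenated benzyl step

The compounds below may be only part of what the source reports. "The series", "measured", "known", "first", "only" and "open" are said of these compounds alone.

Measured compounds:
compound 1, `Cc1ccc(NC(=S)NC(=O)c2ccc(OCc3ccc(C(F)(F)F)cc3)cc2)cc1-c1nc2ccccc2[nH]1`: 72400 nM
compound 2, `Cc1ccc(NC(=O)NC(=O)c2ccc(OCc3ccccc3)cc2)cc1-c1nc2ccccc2[nH]1`: 30100 nM

In a functional assay on SW-620 cells (Homo sapiens) for inhibition, read by MTT assay, with a stated time of 48 h (a lower number here means a stronger inhibitor, a higher number a weaker inhibitor), compound 1 gives 72400 nM and compound 2 gives 30100 nM. Compound 2 has the lowest number of the two, and the gap to compound 1 lies beyond the usual scatter; the two differ in more than one place, so the gap is read only as what the two values show.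

Compound 3, `Cc1ccc(NC(=O)NC(=O)c2ccc(OCc3cccc(Cl)c3Cl)cc2)cc1-c1nc2ccccc2[nH]1`, is not yet measured in this assay. The change from compound 2 is 2,3-dichlorophenyl in place of phenyl on a saturated chain carbon bound to an oxygen on an aromatic ring; cut one bond further out it reads benzyl to 2,3-dichlorobenzyl. Among the compounds with values here, no single-point step between measured compounds is known, so the size of this step rests on nothing measured. A small move toward a lower number, or none beyond the scatter, is expected, that is a 1.5-fold lower number from compound 2 to compound 3 (0.18 log units; within the scatter) from compound 2. For compound 3 the value in this assay is estimated at 20000 nM, with a range of 6000 nM to 60000 nM.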

Compound 3, half-maximal inhibitory concentration: 42100 nM
Compound 3: the middle estimate sits 2.1-fold (0.32 log units) below what was measured; low and high end bracket the measured number.
By their numbers in this assay, from the lowest: compounds 2, 3 and 1 (each within the scatter of the next, the first and the last beyond it).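

In this assay the series now has its first single-point reading at this position, and it gives a 1.4-fold higher number from compound 2 to compound 3 (0.15 log units; within the scatter) for 2,3-dichlorophenyl in place of phenyl on the saturated chain carbon bound to an oxygen on an aromatic ring. The two chlorine atoms that enter there therefore leave the number within the scatter in this one pair, which the comparison of compound 1 with compound 2 could not show, as those two differ in more than one place. Nothing available speaks to why this step reads as it does.

From the compounds shown here alone, whether the urea and thiourea forms differ by themselves stays open, as does the share of trifluoromethyl in the gap between compound 1 and compound 2. Going by these compounds, how an amine or a carboxylic acid on this phenyl, or a longer chain in place of benzyl, would read also remains open.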